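Changing the anilide aryl group toward dichlorophenyl on compound 1

The compounds below may be only part of what the source reports. "The series", "measured", "known", "first", "only" and "open" are said of these compounds alone.

Compound 1 `Cc1ccc(NC(=O)CN2C(=O)/C(=N\NC(=O)Cn3ccc(=O)c(O)c3C)c3ccccc32)cc1` is the reference point in a functional assay on A549 cells (Homo sapiens) for cytotoxicity, read by MTT assay, with a stated time of 48 h (on this read-out lower numbers stand for an effect already at smaller amounts and higher numbers for an effect only at larger amounts of compound), where compound 1 gives 47500 nM. Among the two numbers recorded in this assay it is the higher one; its nearest neighbour is compound 3 `Cc1cccc(NC(=O)CN2C(=O)/C(=N\NC(=O)Cn3ccc(=O)c(O)c3C)c3ccccc32)c1C`, which in this assay gives 39200 nM, a difference of a 1.2-fold lower number from compound 1 to compound 3 (0.08 log units; within the scatter). Compound 2 `Cc1c(O)c(=O)ccn1CC(=O)N/N=C1\C(=O)N(CC(=O)Nc2ccccc2Cl)c2ccccc21` gives only a limit in this assay, > 100000 nM (the limit of > 100000 nM in this assay, at which 1 of the 3 values shown sits). The steps in this assay are therefore an at least 2.1-fold higher number from compound 1 to compound 2 (0.32 log units; beyond the scatter) and an at least 2.5-fold lower number from compound 2 to compound 3 (0.40 log units; beyond the scatter).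

Compound 4 `Cc1c(O)c(=O)ccn1CC(=O)N/N=C1\C(=O)N(CC(=O)Nc2ccc(Cl)cc2Cl)c2ccccc21` has not yet been measured. It differs from compound 1 by 2,4-dichlorophenyl in place of 4-methylphenyl on an amide-type nitrogen. Among the measured compounds shown here, two measured steps bear on this change: the exchange of 4-methylphenyl for 2-chlorophenyl weakened the effect beyond the scatter, while the exchange for 2,3-dimethylphenyl stayed within it. The change toward 2,4-dichlorophenyl keeps a chlorine on the ring and adds a second one, so a step in the same direction as from compound 1 to compound 2 is expected, and it may again end at the limit of this assay. The expected step is a 1.9-fold higher number from compound 1 to compound 4 (0.28 log units; within the scatter). Compound 4 is estimated to give 90000 nM in this assay, within a range from 40000 nM to 200000 nM.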

Compound 4, half-maximal effective concentration: 61500 nM
Estimate against measurement, compound 4: 1.5-fold (0.17 log units) above, within the range that was stated.
By their numbers in this assay, from the lowest: compounds 3, 1 and 4 (each within the scatter of the next). At a limit, above all of these: compound 2.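

The 2,4-dichlorophenyl group on the amide-type nitrogen leaves the number where 4-methylphenyl and 2,3-dimethylphenyl put it, with a 1.3-fold higher number from compound 1 to compound 4 (0.11 log units; within the scatter) and a 1.6-fold higher number from compound 3 to compound 4 (0.20 log units; within the scatter), so a chlorine on this ring does not by itself go with a loss of effect in this assay. Chloro in place of hydrogen on an aromatic carbon gives an at least 1.6-fold lower number from compound 2 to compound 4 (0.21 log units; that floor lies within the scatter), and with that floor inside the scatter, this pair shows no firm separation. Compound 2 remains the only compound set apart beyond the scatter, from compound 1 and compound 3 alone, and its value is a limit: the limit of > 100000 nM in this assay, at which 1 of the 4 values shown sits.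

All the readable numbers lie within the scatter of their neighbours, so the compounds shown leave open whether any group at this place can bring the effect down to clearly smaller amounts of compound. Nor do they tell how an aryl group carrying an amine or a carboxylic acid, or a longer chain in place of the ((4-methylphenyl)carbamoyl)methyl group, would behave in this assay.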